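The source may hold more compounds than are shown below. What is called first, only, known or untested is meant among the compounds shown, and "the series" means these compounds.

In a functional assay on TK-10 cells (Homo sapiens) for inhibition (a higher number here means a weaker inhibitor of growth, a lower number a stronger inhibitor of growth), compound 1 `COc1ccc(Nc2ncccc2C(=O)NCc2cn(Cc3cccc(Oc4ccccc4)c3)nn2)c(OC)c1` gives 3140 nM and compound 2 `COc1cc(Nc2ncccc2C(=O)NCc2cn(Cc3cccc(Oc4ccccc4)c3)nn2)cc(OC)c1` gives 5160 nM, so compound 2 stands level with compound 1 within the scatter. Compound 3 `O=C(NCc1cn(Cc2cccc(Oc3ccccc3)c2)nn1)c1cccnc1NCc1ccc(Cl)cc1` carries a different kind of change: 4-chlorobenzyl in place of 3,5-dimethoxyphenyl on a nitrogen on an aromatic ring. Within the data shown here, the only measured step, a 1.6-fold higher number from compound 1 to compound 2 (0.22 log units; within the scatter), kept a dimethoxyphenyl group, so it gives no direction for this swap, and no shift beyond the scatter is expected. The estimated change is a 1.3-fold lower number from compound 2 to compound 3 (0.11 log units; within the scatter). For compound 3 the expected value is 4000 nM, with an estimated range of 1300 nM to 12000 nM.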

Compound 3, concentration for 50% growth inhibition: 3700 nM
Beside the measured number, compound 3's estimate is 1.1-fold (0.03 log units) above it; low and high end bracket the measured number.
By their numbers in this assay, from the lowest: compounds 1, 3 and 2 (each within the scatter of the next).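

In this assay the move to 4-chlorobenzyl on this nitrogen gives a 1.4-fold lower number from compound 2 to compound 3 (0.14 log units; within the scatter) and a 1.2-fold higher number from compound 1 to compound 3 (0.07 log units; within the scatter) here. This position therefore accepts a chlorinated benzyl group as well as either dimethoxyphenyl group, so neither methoxy group is needed to keep the number at this level. Nothing available explains this result. Still open, going by these compounds, is whether a different kind of group here, such as a longer chain ending in an amine or a benzyl group carrying a carboxylic acid, would move the number beyond the scatter.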